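Propyl in place of chloro on the compound 2 scaffold

This account rests on a few compounds, and the source may have more. Where it says the series, first, only, none or still open, it means among the compounds named here.

Among the compounds with values here, in a functional assay on the whole organism (brain) with Mus musculus as the target (on this read-out higher numbers stand for an effect only at larger amounts of compound and lower numbers for an effect already at smaller amounts), compound 2 `Clc1ccc(OCCc2c[nH]cn2)cc1` gives 0.78 mg/kg, the only actual number among the three compounds measured so far. Compound 1 `O=[N+]([O-])c1ccc(CSCc2c[nH]cn2)cc1` is reported only as a limit, > 10 mg/kg. Compound 3 `Clc1cc(Cl)cc(OCCc2c[nH]cn2)c1` is also reported only as a limit, > 10 mg/kg. The series therefore stands as follows: the limit of > 10 mg/kg in this assay, at which 2 of the 3 values shown sit. Within the data shown here, compound 2 is the sole numerical anchor, and no measured pair differs in one place alone, so no single change has a measured size.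

The next compound is compound 4 `CCCc1ccc(OCCc2c[nH]cn2)cc1`, which keeps the shared core of compound 2 and carries propyl in place of chloro on an aromatic carbon.

Without a measured step to scale from, the size of this change in this assay can only be estimated. A small move toward larger doses is expected, rather than a drop to the limit. Among the measured compounds shown here, the lean in that direction rests on compound 3, whose limit is > 10 mg/kg, and the wide range reflects the single number available. The estimated step is a 2.6-fold higher number from compound 2 to compound 4 (0.41 log units; beyond the scatter). The expected value for compound 4 is 2 mg/kg, with an estimated range of 0.5 mg/kg to 8 mg/kg.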

Compound 4, dose for half-maximal effect: 1.6 mg/kg
Estimate against measurement, compound 4: 1.3-fold (0.10 log units) above, within the range that was stated.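

Within the data shown here, the first change that can be read at a single place is on an aromatic carbon, para to a group of 8 heavy atoms, and in this assay it is a 2.1-fold higher number from compound 2 to compound 4 (0.31 log units; beyond the scatter) and remains modest. This position therefore takes propyl, with 3 heavy atoms, in place of chloro, with 1 heavy atom, at the cost of only this modest move toward larger doses, and compound 4 still gives an actual number rather than a limit. With a second number beside compound 2, the position has a first measured size of change, while limits remain as common as numbers in the series: the limit of > 10 mg/kg in this assay, at which 2 of the 4 values shown sit.

One step cannot separate the loss of chloro from the arrival of propyl, or show whether the size of the step follows the length of the chain. From the compounds shown here alone, whether methoxy, an amine, a carboxylic acid or a longer chain such as butyl on the same aromatic carbon would stay close to compound 2 or compound 4, or would reach the limit, remains open.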